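Hydroxy for chloro on a cinnamamide of compound 2

The source may report more compounds than this note shows. Statements on the series, on what has been measured and on what is new or still open speak of the compounds shown alone.

Of the compounds shown here, three have been tested in a functional assay on the whole organism (Hindlimb, strain albino) with Mus musculus as the target, in the maximal electroshock model, with a stated time of 0.5 h; on this read-out lower numbers stand for an effect already at smaller amounts and higher numbers for an effect only at larger amounts of compound. Compound 1 `CC(=O)N1N=C(Nc2nc3ccccc3s2)CC1OC1=CC=C1` gives 382 umol/kg. Compound 2 `O=C(/C=C/c1ccc(Cl)cc1)Nc1nc2ccc(Cl)cc2s1` gives 204 umol/kg. Compound 3 `O=C(/C=C/c1ccc(Cl)cc1)Nc1nc2ccccc2s1` gives 367 umol/kg. Compound 2 thus shows the lowest of the three numbers, but both neighbours lie within the scatter of it, so no order among the three can be read from these values. Among the measured compounds shown here, the one single-point step that has been measured is a 1.8-fold higher number from compound 2 to compound 3 (0.26 log units; within the scatter), and it concerns the chloro on the core, not the 4-chlorophenyl group.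

Compound 4 `O=C(/C=C/c1ccc(O)cc1)Nc1nc2ccc(Cl)cc2s1` differs from compound 2 by hydroxy in place of chloro on an aromatic carbon. For the measured compounds named here, no measured step touches that ring, so nothing in the data points in either direction; the only measured step, that from compound 2 to compound 3, stayed within the scatter. The expectation is therefore a step of about a 1.6-fold higher number from compound 2 to compound 4 (0.20 log units; within the scatter) in this assay, no larger than the scatter. Compound 4 is estimated to give 320 umol/kg, with a likely range from 130 umol/kg to 800 umol/kg.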

Compound 4, dose for half-maximal effect: 322 umol/kg
The estimate for compound 4 lay 1.0-fold (0.00 log units) below the measured number, and the stated range covers the measured number.
By their numbers in this assay, from the lowest: compounds 2, 4, 3 and 1 (each within the scatter of the next).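

Among the compounds shown here, until now the only single-point step concerned the chloro on the core, so the 4-chlorophenyl group of the cinnamamide had not been probed. In this assay, 4-chlorophenyl to 4-hydroxyphenyl gives a 1.6-fold higher number from compound 2 to compound 4 (0.20 log units; within the scatter), so this place on the ring takes a hydroxy, with its hydrogen-bond donor and acceptor, in place of chloro without a step beyond the scatter. The data shown offer no explanation for this result.

The compounds shown leave open whether a different group here, such as an amine, a methoxy or a carboxylic acid, would give a step beyond the scatter. They also leave open how hydroxy in place of chloro on this ring reads when the core carries hydrogen instead of chloro, as in compound 3.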